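Moving the fluorine on the pendant phenyl ring

The source may report more compounds than this note shows. Statements on the series, on what has been measured and on what is new or still open speak of the compounds shown alone.

Measured compounds:
- compound 1, `Cc1c(-c2cc(-c3ccccc3Cl)no2)cnn1C1CCNCC1`: 18 nM
- compound 2, `Fc1cccc(Cl)c1-c1cc(-c2cnn(C3CCNCC3)c2)on1`: 48 nM
- compound 3, `Cc1c(-c2cc(-c3c(F)cccc3Cl)no2)cnn1C1CCNCC1`: 6 nM

In an assay on isolated protein for positive allosteric modulation of Neuronal acetylcholine receptor; alpha4/beta2 (Homo sapiens) (a higher number here means that more compound is needed for the effect, a lower number that less compound is needed), compound 2 gives the highest number of the three; compound 1 sits closest to it, and compound 3 furthest away, both steps lying beyond the scatter. Compound 4, `Fc1cccc(-c2cc(-c3cnn(C4CCNCC4)c3)on2)c1Cl`, keeps every atom of compound 2 but joins them differently: 2-chloro-3-fluorophenyl in place of 2-chloro-6-fluorophenyl on an aromatic carbon. Among the compounds with values here, no measured pair shows this change. The two steps that come nearest are a 3.0-fold lower number from compound 1 to compound 3 (0.48 log units; beyond the scatter), where a fluorine is added to the 2-chlorophenyl ring, and an 8.0-fold lower number from compound 2 to compound 3 (0.90 log units; beyond the scatter), where a methyl is added to the shared core. Neither tells where on the phenyl ring the fluorine is best placed, only that its presence at the 2-chloro-6-fluorophenyl position accompanied a modest gain. Moving it away from that position is therefore expected to give no gain and possibly a small loss, with the step from compound 2 to compound 4 estimated as a 1.4-fold higher number from compound 2 to compound 4 (0.13 log units; within the scatter). Compound 4 is accordingly expected to give 65 nM, within a range of 20 nM to 200 nM.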

Compound 4, half-maximal effective concentration: 230 nM
Estimate against measurement, compound 4: 3.5-fold (0.55 log units) below; the whole stated range lies below it.
By their numbers in this assay, from the lowest: compound 3; then compound 1; then compound 2; then compound 4.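

In this assay, there is a 4.8-fold higher number from compound 2 to compound 4 (0.68 log units; beyond the scatter) when 2-chloro-3-fluorophenyl replaces 2-chloro-6-fluorophenyl, and this step lies beyond the scatter. The earlier steps shown here showed what adding a fluorine or a methyl did, whereas here the atoms stay the same and only their arrangement on the phenyl ring differs, so the placement of the fluorine alone changes the number. Nothing shown here accounts for the difference between the two arrangements.

The compounds shown leave open whether adding the methyl of compound 3 to the shared core of compound 4 would lower the number as it does for compound 2. They also leave open how a methoxy group or a nitrile would compare with the fluorine on this ring.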